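The compounds below may be only part of what the source reports. "The series", "measured", "known", "first", "only" and "open" are said of these compounds alone.

Compound 2 `COc1ccc2[nH]c3c(c2c1)CCNC31CCN(Cc2ccc(F)c(Cl)c2F)CC1` gives the highest of the two numbers in an assay on FRT cells for positive allosteric modulation of Cystic fibrosis transmembrane conductance regulator variant N1303K (Homo sapiens), in the presence of a further agent that is not named here (on this read-out higher numbers stand for an effect only at larger amounts of compound and lower numbers for an effect already at smaller amounts), at 4500 nM; compound 1 `COc1ccc2[nH]c3c(c2c1)CCNC31CCN(Cc2ccc(Cl)cc2Cl)CC1` gives 1800 nM. Among the compounds with values here, the only measured step, a 2.5-fold higher number from compound 1 to compound 2 (0.40 log units; beyond the scatter), bears on the same position. Compound 3 `COc1ccc2[nH]c3c(c2c1)CCNC31CCN(Cc2cc(F)ccc2F)CC1` differs from compound 2 by 2,5-difluorophenyl in place of 3-chloro-2,4-difluorophenyl on a saturated chain carbon bound to an amine nitrogen in a ring. Within the data shown here, no measured pair removes chlorine from this ring, so the direction is uncertain; a change of similar size to the one seen is plausible, but a step within the scatter is expected, a 1.1-fold higher number from compound 2 to compound 3 (0.05 log units; within the scatter). Compound 3 is therefore estimated at 5000 nM, within 2000 nM to 13000 nM.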

Compound 3, half-maximal effective concentration: 11100 nM
Estimate against measurement, compound 3: 2.2-fold (0.35 log units) below; the measured number falls inside the stated range.
By their numbers in this assay, from the lowest: compound 1; then compound 2; then compound 3.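

In this assay the ring without chlorine, 2,5-difluorophenyl, gives the highest number of the series, with a 2.5-fold higher number from compound 2 to compound 3 (0.39 log units; beyond the scatter) and a 6.2-fold higher number from compound 1 to compound 3 (0.79 log units; beyond the scatter) in the same direction. Among these compounds, both chlorine-bearing rings therefore give lower numbers than the ring without chlorine, and none goes against this. Nothing available accounts for the size of either step.

On these data alone, the change from 3-chloro-2,4-difluorophenyl to 2,5-difluorophenyl alters chlorine and the fluorine pattern together, so their separate contributions remain open. Also open, as far as these compounds go, is how a methoxy group or a nitrile on this ring would compare.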